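This account rests on a few compounds, and the source may have more. Where it says the series, first, only, none or still open, it means among the compounds named here.

Compound 1 `COc1cc(/C=C/C(=O)/C=C/c2ccccc2)ccc1OCc1cn(CCCCOc2cc(=O)oc3ccccc23)nn1` is the starting point of this series. In a functional assay on COLO 205 cells (Homo sapiens) for inhibition, read by sulforhodamine B assay, with a stated time of 48 h, tested at 50 uM (a higher number here means more inhibition of growth at the concentration tested, a lower number less inhibition of growth), compound 1 gives 31%. Compound 2 `COc1cc(/C=C/C(=O)/C=C/c2ccco2)ccc1OCc1cn(CCCCOc2cc(=O)oc3ccccc23)nn1` carries furan-2-yl in place of phenyl on a double-bonded chain carbon bound to a double-bonded chain carbon and in this assay compound 2 gives 43%, so that the change produced a number 12 percentage points higher from compound 1 to compound 2 (beyond the scatter). Compound 3 `COc1cc(/C=C/C(=O)/C=C/c2ccccc2)ccc1OCc1cn(CCOc2cc(=O)oc3ccccc23)nn1` has a different core; how that core differs from the core of compound 1 is not broken down here. In this assay compound 3 gives 54%, the highest of the three values, beyond the scatter from both compound 1 and compound 2.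

Compound 4 `COc1cc(/C=C/C(=O)/C=C/c2ccco2)ccc1OCc1cn(CCOc2cc(=O)oc3ccccc23)nn1` is not yet measured. It differs from compound 3 by furan-2-yl in place of phenyl on a double-bonded chain carbon bound to a double-bonded chain carbon, the same change that was made from compound 1 to compound 2. The step of a number 9 percentage points higher from compound 3 to compound 4 (within the scatter) is expected, because a number 12 percentage points higher from compound 1 to compound 2 (beyond the scatter) gave a modest rise on the other core. In this assay compound 4 is therefore estimated at 63%, with a range expected from 48% to 78%.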

Compound 4, percent growth inhibition at one concentration: 68%
The estimate for compound 4 lay 5 percentage points below the measured number; the range from low to high includes it.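

In this assay, furan-2-yl in place of phenyl gave a number 14 percentage points higher from compound 3 to compound 4 (beyond the scatter), and the change carried over from one core to the other with a step of matching size: the same change on two cores in this assay, a number 12 percentage points higher (beyond the scatter) from compound 1 to compound 2 and a number 14 percentage points higher (beyond the scatter) from compound 3 to compound 4, 2 percentage points apart, within the scatter of two such steps. This agreement rests on a single pair of cores, tested in one assay at one concentration. It does not show that the same rise would appear on any further core, and it gives no reason for the rise.

The compounds shown leave open whether another group in that place, such as thienyl or an amine-bearing phenyl, would give a similar step. They also leave open how a longer chain on the triazole would behave.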